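The compounds below may be only part of what the source reports. "The series", "measured", "known", "first", "only" and "open" are said of these compounds alone.

Working notes on the series. In an ADME assay on CCRF-CEM cells (Homo sapiens) for antiproliferative activity, with a stated time of 48 h (a lower number here means a stronger inhibitor, a higher number a weaker inhibitor), compound 1 (`C=C(Br)C(=O)Nc1ccc(C(=O)/C=C/c2ccccc2)cc1`) gives 1500 nM, compound 2 (`C=C(Br)C(=O)Nc1ccc(C(=O)/C=C/c2ccc(OC)cc2)cc1`) gives 1100 nM and compound 3 (`C=C(Br)C(=O)Nc1ccc(C(=O)/C=C/c2cccc(OC)c2)cc1`) gives 1800 nM. Compound 3 stands within the scatter of both others, with a 1.2-fold higher number from compound 1 to compound 3 (0.08 log units; within the scatter) and a 1.6-fold higher number from compound 2 to compound 3 (0.21 log units; within the scatter).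

Compound 4 (`C=C(Br)C(=O)Nc1ccc(C(=O)/C=C/c2cccc(OC)c2OC)cc1`) differs from compound 3 by one change: methoxy in place of hydrogen on an aromatic carbon. The new methoxy replaces hydrogen on an aromatic carbon, ortho to a large group and ortho to a methoxy group. Two measured steps make the same kind of replacement: a 1.4-fold lower number from compound 1 to compound 2 (0.13 log units; within the scatter) and a 1.2-fold higher number from compound 1 to compound 3 (0.08 log units; within the scatter). Both lie within the scatter and they point in opposite directions. Among the measured compounds shown here, no measured compound carries a methoxy ortho to a large group, so the new place remains untested and the range stays wide.

No change beyond the scatter is expected in this assay, and no direction is favoured with any confidence. The expected step is a 1.3-fold lower number from compound 3 to compound 4 (0.11 log units; within the scatter). For compound 4 the estimated value is 1400 nM, with an expected range from 650 nM to 3000 nM.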

Compound 4, half-maximal inhibitory concentration: 710 nM
Compound 4: middle estimate off by 2.0-fold (0.29 log units), on the high side; the range from low to high includes it.
By their numbers in this assay, from the lowest: compounds 4, 2, 1 and 3 (each within the scatter of the next, the first and the last beyond it).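

In this assay, among the compounds shown here, methoxy in place of hydrogen on an aromatic carbon, ortho to a large group and ortho to a methoxy group, gives the first step of this kind beyond the scatter: a 2.5-fold lower number from compound 3 to compound 4 (0.40 log units; beyond the scatter). For the compounds shown here, the position therefore carries a methoxy without a higher number, and the earlier replacements, both within the scatter, gave no sign of a step of this size. The step is still modest and does not stand apart from the same change on the other core: the same change on two cores in this assay, a 1.4-fold lower number (0.13 log units; within the scatter) from compound 1 to compound 2 and a 2.5-fold lower number (0.40 log units; beyond the scatter) from compound 3 to compound 4, 1.9-fold (0.27 log units) apart, within the scatter of two such steps.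

Compound 4 is the only compound shown with a methoxy at this place, and it also keeps the methoxy of compound 3, so the contribution of each group alone stays open. Also open, going by these compounds, is how a hydroxy, an amine or a longer alkoxy chain at this place would compare.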